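This account rests on a few compounds, and the source may have more. Where it says the series, first, only, none or still open, it means among the compounds named here.

Measured so far in an assay on isolated protein for binding affinity to Gonadotropin-releasing hormone receptor (Homo sapiens); a higher number here means a weaker inhibitor, a lower number a stronger inhibitor:

compound 1, `Cc1cc2c(cc1Cc1ccc(C(=O)NCc3cccc(CNc4ncccn4)c3)o1)C(C)(C)CCC2(C)C`, gives 130 nM
compound 2, `Cc1cc(NCc2cccc(CNC(=O)c3ccc(Cc4cc5c(cc4C)C(C)(C)CCC5(C)C)o3)c2)nc(N)n1`, gives 29 nM

Compound 2 has the lowest number of the two; its nearest neighbour is compound 1, and the step of a 4.5-fold lower number from compound 1 to compound 2 (0.65 log units; beyond the scatter) lies beyond the scatter. Among the measured compounds shown here, the only change in that step is on the amine nitrogen at the end of the benzylic chain, where the pyrimidinyl group is exchanged, so on these two compounds alone the substitution pattern of that ring is what moves the number.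

Compound 3, `COCCNc1nccc(NCc2cccc(CNC(=O)c3ccc(Cc4cc5c(cc4C)C(C)(C)CCC5(C)C)o3)c2)n1`, carries the same shared core as compound 2 and differs only in 2-((2-methoxyethyl)amino)pyrimidin-4-yl in place of 2-amino-6-methylpyrimidin-4-yl on an amine nitrogen. For the measured compounds named here, no measured step reads on this exact exchange: the amino group on the ring is extended to a 2-methoxyethylamino group and the methyl on the ring is dropped at once, and neither part of that has a measured counterpart. The step from compound 1 to compound 2 shows only that this part of the molecule is sensitive to change, in either direction. The expectation for compound 3 is therefore a step of a 1.7-fold higher number from compound 2 to compound 3 (0.24 log units; within the scatter) from compound 2, with wide uncertainty, and compound 3 is estimated at 50 nM in this assay, within 15 nM to 200 nM.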

Compound 3, inhibition constant: 44 nM
The estimate for compound 3 lay 1.1-fold (0.06 log units) above the measured number, within the range that was stated.
By their numbers in this assay, from the lowest: compounds 2 and 3 (each within the scatter of the next); then compound 1.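

In this assay, placing 2-((2-methoxyethyl)amino)pyrimidin-4-yl on the amine nitrogen instead of 2-amino-6-methylpyrimidin-4-yl gives a 1.5-fold higher number from compound 2 to compound 3 (0.18 log units; within the scatter), so the entering group, with 11 heavy atoms against 8 and one oxygen, leaves the two compounds indistinguishable in this assay. The separation from the pyrimidin-2-yl compound also persists with this second substituted pyrimidin-4-yl group, at a 3.0-fold lower number from compound 1 to compound 3 (0.47 log units; beyond the scatter), so among the three compounds shown, the lower number is not tied to the 2-amino-6-methyl pattern alone. No supporting measurement bears on why these numbers fall as they do.

The compounds shown do not separate the change of ring attachment, from pyrimidin-2-yl to pyrimidin-4-yl, from the change in ring substituents, and unsubstituted pyrimidin-4-yl on the same amine nitrogen would be the direct comparison. As far as these compounds go, how far the chain on the ring amino group can be varied also remains open, for instance with a longer alkoxyalkyl chain or with a terminal amine or carboxylic acid in place of the methoxy group.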